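Oral Exposure in Monkey: Carboxy Replacing Methanesulfonamido

The source may report more compounds than this note shows. Statements on the series, on what has been measured and on what is new or still open speak of the compounds shown alone.

Compound 1 `CCCCN(c1nc2c(CO)cccc2o1)[C@H](C)c1ccc(-c2ccccc2-c2nnn[nH]2)cc1`: 20.7 nM
Compound 2 `CCCCN(c1nc2c(NC(C)=O)cccc2o1)[C@H](C)c1ccc(-c2ccccc2-c2nnn[nH]2)cc1`: 26.6 nM
Compound 3 `CCCCN(c1nc2c(NS(C)(=O)=O)cccc2o1)[C@H](C)c1ccc(-c2ccccc2-c2nnn[nH]2)cc1`: 49.9 nM

Three compounds sharing one core were dosed in an ADME assay on the whole organism (Macaca fascicularis) for pharmacokinetics, read by LC-MS, using cassette dosing, at a dose of 1 mg/kg by the oral route; a higher number here means more compound in the circulation at the dose given, a lower number less compound in the circulation. Compound 3 gives the highest of the three numbers, 49.9 nM; its nearest neighbour is compound 2, with a 1.9-fold higher number from compound 2 to compound 3 (0.27 log units; within the scatter), and the furthest is compound 1, with a 2.4-fold higher number from compound 1 to compound 3 (0.38 log units; beyond the scatter). The remaining measured step, a 1.3-fold higher number from compound 1 to compound 2 (0.11 log units; within the scatter), is also small.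

Compound 4 `CCCCN(c1nc2c(C(=O)O)cccc2o1)[C@H](C)c1ccc(-c2ccccc2-c2nnn[nH]2)cc1` differs from compound 3 in one place: carboxy in place of methanesulfonamido on an aromatic carbon. Within the data shown here, no measured step introduces a carboxy group, so the only guide is that the three earlier changes at this same aromatic carbon all moved the maximal plasma concentration by modest amounts. A step of similar size is therefore expected, more likely downward than upward, since compound 3 already stands at the top of the measured range, giving an estimated 2.0-fold lower number from compound 3 to compound 4 (0.30 log units; within the scatter). Compound 4 is expected to reach 25 nM in this assay, with a range from 6 nM to 100 nM.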

Compound 4, maximal plasma concentration: 238 nM
Compound 4: the middle estimate sits 9.5-fold (0.98 log units) below what was measured; the measured number lies above the stated range.
By their numbers in this assay, from the lowest: compounds 1, 2 and 3 (each within the scatter of the next, the first and the last beyond it); then compound 4.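

In this assay the aromatic carbon of the shared core proved able to carry a much larger step than the three earlier groups had shown, with a 4.8-fold higher number from compound 3 to compound 4 (0.68 log units; beyond the scatter) on going to carboxy. The same holds against the other two groups, with an 8.9-fold higher number from compound 2 to compound 4 (0.95 log units; beyond the scatter) and with an 11-fold higher number from compound 1 to compound 4 (1.06 log units; beyond the scatter) as well, so that compound 4 stands beyond the scatter of all three and the hydroxymethyl, acetamido and methanesulfonamido compounds differ far less among themselves. Nothing at hand accounts for the size of this step.

On these data alone, whether the higher number belongs to carboxy alone, or would also appear with a methyl ester, a primary carboxamide or a carboxymethyl group on this aromatic carbon, remains open. Also open, as far as these compounds go, is whether carboxy would give a step of this size with a longer chain on the shared core.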